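The source may report more compounds than this note shows. Statements on the series, on what has been measured and on what is new or still open speak of the compounds shown alone.

Measured so far in an ADME assay on MDCK cells (Canis lupus familiaris) for cytotoxicity, read by MTT assay, with a stated time of 72 h; a lower number here means that less compound is tolerated, a higher number that more compound is tolerated:

Compound 1 `C=C(CC(=O)Nc1ccc(Cl)cc1F)C(=O)O` — > 110000 nM
Compound 2 `C=C(CC(=O)Nc1ccc(C(F)(F)F)cc1F)C(=O)O` — > 110000 nM
Compound 3 `C=C(CC(=O)Nc1cc(C(F)(F)F)ccc1F)C(=O)O` — > 110000 nM

Each of these three values is a limit of this assay, not a number: compound 1 shows only the limit > 110000 nM. Compound 2 likewise shows only the limit > 110000 nM. Compound 3 also shows only the limit > 110000 nM. All three sit at the limit of > 110000 nM in this assay, at which 3 of the 3 values shown sit.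

The change from compound 2 to compound 1 is chloro in place of trifluoromethyl on an aromatic carbon. Because both ends are limits, a step that the two limits leave unreadable from compound 2 to compound 1 cannot be read. Compound 4 `C=C(CC(=O)Nc1cc(Cl)ccc1F)C(=O)O` is not yet measured in this assay. It differs from compound 3 by chloro in place of trifluoromethyl on an aromatic carbon. This is the same kind of change as that from compound 2 to compound 1, not the same one: in compound 4 the new group stands meta to a group of 9 heavy atoms and para to a fluoro group, whereas in compound 1 it stands meta to a fluoro group and para to a group of 9 heavy atoms. The cores of compound 2 and compound 3 have the same atoms joined differently; the difference between the two cores is not broken down here.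

Going by the values given here, the step from compound 3 to compound 4 is expected to be a step that the limit leaves unreadable from compound 3 to compound 4, resting on the unreadable earlier step and on the fact that all three values so far sit at the limit of > 110000 nM in this assay, at which 3 of the 3 values shown sit. Compound 4 is expected to give about 150000 nM in this assay, between 70000 nM and 400000 nM, most likely reported again as a limit.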

Compound 4, half-maximal cytotoxic concentration: > 110000 nM
Compound 4: no number, only a limit; the forecaster's own chance of this, stated with the estimate: 85%; the middle value is on the limit's open side.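

In this assay compound 4 gives > 110000 nM, a limit and not a number. No step can be read from compound 3 to compound 4, or from compound 2 to compound 1, because both ends of each pair are limits: the limit of > 110000 nM in this assay, at which 4 of the 4 values shown sit.

The compounds shown leave open what concentration of any of them reaches the half-maximal cytotoxic effect in this assay, and whether chloro in place of trifluoromethyl shifts that concentration.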